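The source may report more compounds than this note shows. Statements on the series, on what has been measured and on what is new or still open speak of the compounds shown alone.

Measured compounds:
compound 1 `CC1(C)Cc2c(sc(NC(=O)c3cccnc3O)c2C(N)=O)C(C)(C)O1`: 190 nM
compound 2 `CC1(C)Cc2c(sc(NC(=O)Cc3ccn[nH]3)c2C(N)=O)C(C)(C)O1`: 136 nM
compound 3 `CC1(C)Cc2c(sc(NC(=O)C3CNC(=O)C3)c2C(N)=O)C(C)(C)O1`: > 10000 nM

In an assay on cells for positive allosteric modulation of Cystic fibrosis transmembrane conductance regulator variant F508del (Homo sapiens), with stated times of 10 min and 7 s, in the presence of a further agent that is not named here (a higher number here means that more compound is needed for the effect, a lower number that less compound is needed), compound 1 gives 190 nM, the highest of the two numbers recorded; compound 2 gives 136 nM, and the step of a 1.4-fold lower number from compound 1 to compound 2 (0.15 log units; within the scatter) stays within the scatter, so the two cannot be ordered. For compound 3 this assay reports only a limit, > 10000 nM; this is the limit described by the limit of > 10000 nM in this assay, at which 1 of the 3 values shown sits, and the step of an at least 52-fold higher number from compound 1 to compound 3 (1.72 log units; beyond the scatter) is large.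

Compound 4 `Cc1n[nH]c(C(=O)Nc2sc3c(c2C(N)=O)CC(C)(C)OC3(C)C)c1Cl` has not yet been measured. It differs from compound 1 in one place: a group of 7 heavy atoms (4 carbon, 2 nitrogen, 1 chlorine; one five-membered aromatic ring with 2 hetero atoms) in place of a group of 7 heavy atoms (5 carbon, 1 nitrogen, 1 oxygen; one six-membered aromatic ring with 1 hetero atom), on a carbonyl carbon. Going by the values given here, two measured steps bear on this change. The step of a 1.4-fold lower number from compound 1 to compound 2 (0.15 log units; within the scatter) shows that a five-membered aromatic ring with 2 hetero atoms, attached through a methylene, leaves the number essentially unchanged. The step of an at least 52-fold higher number from compound 1 to compound 3 (1.72 log units; beyond the scatter) shows that a saturated, non-aromatic 5-oxopyrrolidin-3-yl in the same place pushes the number beyond the limit of this assay. Compound 4 keeps an aromatic ring on the carbonyl carbon, as in compound 1 and compound 2, so no step beyond the scatter is expected in this assay. Compound 4 is therefore estimated at 160 nM, with a range of 50 nM to 600 nM, which would mean an expected step of a 1.2-fold lower number from compound 1 to compound 4 (0.07 log units; within the scatter).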

Compound 4, half-maximal effective concentration: 11 nM
The estimate for compound 4 lay 15-fold (1.16 log units) above the measured number; measured number below the stated range.
By their numbers in this assay, from the lowest: compound 4; then compounds 2 and 1 (each within the scatter of the next). At a limit, above all of these: compound 3.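

In this assay, the earlier aromatic groups could not be told apart, but the chlorine-bearing five-membered aromatic ring on the carbonyl carbon separates clearly from both, with a 17-fold lower number from compound 1 to compound 4 (1.24 log units; beyond the scatter) and a 12-fold lower number from compound 2 to compound 4 (1.09 log units; beyond the scatter). An aromatic ring in this place is therefore not enough to fix the number: compound 1, compound 2 and compound 4 all carry one, yet compound 4 stands apart from the other two by a large step. The span at this position also widens with an at least 900-fold lower number from compound 3 to compound 4 (2.95 log units; beyond the scatter), and one end of that step is not a number but a limit: the limit of > 10000 nM in this assay, at which 1 of the 4 values shown sits.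

The compounds shown cannot say which feature of the new group goes with the lower number, as the chlorine, the methyl group and the five-membered ring sitting on the carbonyl carbon without a methylene all arrive together. On these data alone, the same ring bearing hydrogen, fluorine or a nitrile in place of the chlorine, or the chlorine-bearing ring attached through a methylene, remains open.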